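This account rests on a few compounds, and the source may have more. Where it says the series, first, only, none or still open, it means among the compounds named here.

Compound 1 `c1ccc(-c2ccc(-c3ccc(-c4nc5ccccc5[nH]4)cc3)cc2)cc1`: 100000 nM
Compound 2 `Oc1cccc2[nH]c(-c3ccc(-c4ccc(-c5ccccc5)cc4)cc3)nc12`: 9040 nM

In a functional assay on HOP-62 cells (Homo sapiens) for inhibition, read by sulforhodamine B assay (on this read-out lower numbers stand for stronger inhibition of growth and higher numbers for weaker inhibition of growth), compound 2 holds the lower of the two numbers, at 9040 nM. Compound 3 `Oc1cccc2[nH]c(-c3ccc(-c4ccc(-c5ccc(C(F)(F)F)cc5)cc4)cc3)nc12` differs from compound 2 by trifluoromethyl in place of hydrogen on an aromatic carbon, with trifluoromethyl in place of hydrogen on an aromatic carbon, para to a large group. Going by the values given here, the only measured step, an 11-fold lower number from compound 1 to compound 2 (1.04 log units; beyond the scatter), concerns hydroxy at another place and bears only indirectly. Among the compounds with values here, no measured step tests trifluoromethyl, so no shift beyond the scatter is expected, and either direction remains open. The expected change is a 1.1-fold lower number from compound 2 to compound 3 (0.05 log units; within the scatter). Compound 3 is estimated at 8000 nM, with an expected range of 2500 nM to 30000 nM.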

Compound 3, concentration for 50% growth inhibition: 3200 nM
Compound 3: the middle estimate sits 2.5-fold (0.40 log units) above what was measured; the measured number falls inside the stated range.
By their numbers in this assay, from the lowest: compound 3; then compound 2; then compound 1.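

In this assay, the change from phenyl to 4-(trifluoromethyl)phenyl gives a 2.8-fold lower number from compound 2 to compound 3 (0.45 log units; beyond the scatter). This aromatic carbon, para to a large group, therefore responds to substitution, and growth inhibition strengthens further on a compound that already carries the hydroxy. No available evidence explains this step. On these data alone, whether the step is specific to trifluoromethyl or would also appear with a methoxy group, an amine or a carboxylic acid at this carbon stays open. Also open, as far as these compounds go, is whether trifluoromethyl would give a similar step without the hydroxy.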